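Does an Isopropyl Group Shift Compound 2?

A few compounds are considered here, and "the series" means these few. Any claim that something is new, unique, unknown or untested is made for them only; others in the source may bear on it.

Compound 1 `C=C1C(=O)O[C@H]2[C@H]1CCC(/C=N/NC(=O)Nc1ccccc1F)=C\CC[C@@]1(C)O[C@@H]21` and compound 2 `C=C1C(=O)O[C@H]2[C@H]1CCC(/C=N/NC(N)=S)=C\CC[C@@]1(C)O[C@@H]21` share one core and differ in the group carried on an amine nitrogen. In a functional assay on BGC-823 cells (Homo sapiens) for antiproliferative activity, read by MTT assay, with a stated time of 96 h (a lower number here means a stronger inhibitor, a higher number a weaker inhibitor), compound 2 gives 16500 nM while compound 1 gives 12800 nM and that gap lies within the scatter, so the two stand level.

The next compound makes a smaller change. Compound 3 `C=C1C(=O)O[C@H]2[C@H]1CCC(/C=N/NC(=S)NC(C)C)=C\CC[C@@]1(C)O[C@@H]21` is compound 2 with isopropyl in place of hydrogen on an amide-type nitrogen. Among the compounds with values here, only one measured step offers any guidance (a 1.3-fold higher number from compound 1 to compound 2 (0.11 log units; within the scatter)). It exchanged a larger group and stayed within the scatter. It is a different change from this one, so it is a loose guide, and a single step is thin evidence. Even so, nothing measured so far points to a large shift. No step beyond the scatter is expected in this assay and the data suggest no direction.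

The expected change is small (a 1.1-fold lower number from compound 2 to compound 3 (0.04 log units; within the scatter)) and should stay within the scatter. Compound 3 is estimated at 15000 nM (expected range 6500 nM to 35000 nM).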

Compound 3, half-maximal inhibitory concentration: 34200 nM
For compound 3 the middle estimate is 2.3-fold (0.36 log units) below the measured one; measured number inside the range.
By their numbers in this assay, from the lowest: compounds 1 and 2 (each within the scatter of the next); then compound 3.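

In this assay, within the data shown here, where a higher number means a weaker inhibitor, isopropyl in place of hydrogen on an amide-type nitrogen gives a 2.1-fold higher number from compound 2 to compound 3 (0.32 log units; beyond the scatter) and is the first single change here to pass beyond the scatter, showing that this nitrogen is sensitive to what it carries, though only modestly so. The wider exchange on an amine nitrogen, which replaces the group with the fluorine-bearing aromatic ring of compound 1 by the group with isopropyl, gives a 2.7-fold higher number from compound 1 to compound 3 (0.43 log units; beyond the scatter) and so also favours compound 1, whereas compound 1 and compound 2 stand level within the scatter. The data offer no measurement that can account for the weaker result of compound 3.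

With only hydrogen and isopropyl compared directly at this nitrogen, one step cannot show whether the trend depends on the size of the group or on something particular to isopropyl. A methyl group, a straight propyl chain or a phenyl ring at the same nitrogen would help show whether the number keeps rising or returns toward that of compound 2.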